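The source may report more compounds than this note shows. Statements on the series, on what has been measured and on what is new or still open speak of the compounds shown alone.

Measured compounds in a functional assay on HT-29 cells (Homo sapiens) for cytotoxicity, read by MTT assay, with a stated time of 72 h; on this read-out lower numbers stand for stronger inhibition and higher numbers for weaker inhibition:

- compound 1 `CN(C)CCn1cnnc1-c1cc(Oc2ccc(NC(=O)N/N=C/c3ccc(O)c(O)c3)cc2F)ccn1` — 1890 nM
- compound 2 `CN(C)CCn1cnnc1-c1cc(Oc2ccc(NC(=O)N/N=C/c3cc(C(C)(C)C)cc(C(C)(C)C)c3O)cc2F)ccn1` — 680 nM
- compound 3 `CN(C)CCn1cnnc1-c1cc(Oc2ccc(NC(=O)N/N=C/c3ccc(O)cc3)cc2F)ccn1` — 1920 nM

Compound 3 has the highest number of the three. Its nearest neighbour is compound 1: the step of a 1.0-fold higher number from compound 1 to compound 3 (0.01 log units; within the scatter) is within the scatter, so the two are not distinguishable on this read-out. Going by the values given here, compound 2 is the furthest from compound 3, with a clearly lower number, but the two differ in more than one place and no single step connects them.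

Compound 4 `COc1ccc(/C=N/NC(=O)Nc2ccc(Oc3ccnc(-c4nncn4CCN(C)C)c3)c(F)c2)c(OC)c1OC` carries 2,3,4-trimethoxyphenyl in place of 4-hydroxyphenyl on a carbon with a double bond to nitrogen.

Among the compounds with values here, only one measured step touches the same ring: from compound 1 to compound 3, hydrogen in place of hydroxy on an aromatic carbon, and it moved nothing beyond the scatter. Within the data shown here, no measured step shows what a methoxy, let alone three, does on this ring, and the lower number of compound 2 comes with a different substitution pattern and cannot be assigned to any one change. The expected step is therefore estimated as a 1.3-fold lower number from compound 3 to compound 4 (0.11 log units; within the scatter), with the range left wide. Compound 4 is estimated at 1500 nM in this assay, between 500 nM and 4500 nM.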

Compound 4, half-maximal inhibitory concentration: 3970 nM
Estimate against measurement, compound 4: 2.6-fold (0.42 log units) below; the measured number falls inside the stated range.
By their numbers in this assay, from the lowest: compound 2; then compounds 1 and 3 (each within the scatter of the next); then compound 4.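

In this assay, the group on the carbon with a double bond to nitrogen can move the number beyond the scatter, which the loss of one hydroxy did not do (a 1.0-fold higher number from compound 1 to compound 3 (0.01 log units; within the scatter)): 2,3,4-trimethoxyphenyl in place of 4-hydroxyphenyl gives a 2.1-fold higher number from compound 3 to compound 4 (0.32 log units; beyond the scatter), and 2,3,4-trimethoxyphenyl in place of 3,4-dihydroxyphenyl gives a 2.1-fold higher number from compound 1 to compound 4 (0.32 log units; beyond the scatter). Both steps are modest and point the same way, so at this position, among these compounds, replacing the hydroxy-bearing phenyl groups with the trimethoxyphenyl group goes with weaker inhibition. No supporting measurement bears on the reason for this shift.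

Each step removes all hydroxy groups and adds three methoxy groups at once, so the compounds shown do not separate the loss of hydroxy from the gain of methoxy, and a phenyl carrying a single methoxy would be the closest test of that. Also open, going by these compounds, is where a phenyl carrying an amine or a carboxylic acid in this place would fall on this read-out.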